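Adding a Second Hydroxy to Compound 2

This account rests on a few compounds, and the source may have more. Where it says the series, first, only, none or still open, it means among the compounds named here.

In a functional assay on DU-145 cells (Homo sapiens) for inhibition, read by MTT assay, with a stated time of 72 h (a lower number here means a stronger inhibitor, a higher number a weaker inhibitor), compound 2 (`O=C1C(N2CCN(c3ccccc3)CC2)=CC(=O)c2c(O)cccc21`) gives 15200 nM, compound 1 (`O=C1C=C(N2CCN(c3ccccc3)CC2)C(=O)c2ccccc21`) gives 9900 nM, and compound 3 (`O=C1C(N2CCN(c3ccc(F)cc3)CC2)=CC(=O)c2c(O)cccc21`) gives 22400 nM. Compound 2 lies within the scatter of each of the other two. Compound 4 (`O=C1C=C(N2CCN(c3ccccc3)CC2)C(=O)c2c(O)ccc(O)c21`) differs from compound 2 by hydroxy in place of hydrogen on an aromatic carbon, para to a hydroxy group. The same kind of change gave a 1.5-fold higher number from compound 1 to compound 2 (0.19 log units; within the scatter). Fluoro in place of hydrogen, a less direct guide, gave a 1.5-fold higher number from compound 2 to compound 3 (0.17 log units; within the scatter). No step beyond the scatter is therefore expected in this assay. The estimated step is a 1.2-fold lower number from compound 2 to compound 4 (0.07 log units; within the scatter). For compound 4 the expected value is 13000 nM, with an estimated range of 4500 nM to 30000 nM.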

Compound 4, half-maximal inhibitory concentration: 1300 nM
Beside the measured number, compound 4's estimate is 10-fold (1.00 log units) above it, outside the stated range (below it).
By their numbers in this assay, from the lowest: compound 4; then compounds 1, 2 and 3 (each within the scatter of the next, the first and the last beyond it).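

In this assay, hydroxy in place of hydrogen on an aromatic carbon, para to a hydroxy group, gives a 12-fold lower number from compound 2 to compound 4 (1.07 log units; beyond the scatter). For the compounds shown here, the same kind of change elsewhere gave only a 1.5-fold higher number from compound 1 to compound 2 (0.19 log units; within the scatter), so its effect here shows that this position responds far more strongly than the earlier compounds suggested. Nothing available explains the size of this step. The compounds shown leave open whether a methoxy group or an amine at this position would give a comparable step, and whether the first hydroxy group must remain for it.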